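Methoxy on the outer ring of a Mer kinase inhibitor

The source may report more compounds than this note shows. Statements on the series, on what has been measured and on what is new or still open speak of the compounds shown alone.

Compounds measured so far:
Compound 1 `CN(Cc1ccc2nccn2c1)c1nnc(-c2ccccc2)o1`: 15800 nM
Compound 2 `CN(Cc1ccc2nccn2c1)c1nnc(-c2ccc(-c3ccccc3)cc2)o1`: 39.8 nM

These two compounds share one core and were tested in an assay on isolated protein for inhibition of tyrosine-protein kinase Mer (Homo sapiens), read by LC-MS; a higher number here means a weaker inhibitor, a lower number a stronger inhibitor. Compound 1 gives 15800 nM, and compound 2 gives 39.8 nM. For the measured compounds named here, the single step between them, a 400-fold lower number from compound 1 to compound 2 (2.60 log units; beyond the scatter), is large and well beyond the usual scatter, so compound 2 stands as the lower of the two numbers, with compound 1 far above it.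

Compound 3 `COc1ccccc1-c1ccc(-c2nnc(N(C)Cc3ccc4nccn4c3)o2)cc1` has not yet been measured. It differs from compound 2 by a small change: methoxy in place of hydrogen on an aromatic carbon. Going by the values given here, the one measured step, a 400-fold lower number from compound 1 to compound 2 (2.60 log units; beyond the scatter), shows that building out this end of the molecule can shift the number sharply, but it describes adding a whole ring, not decorating an existing one. Among the compounds with values here, no measured pair shows what a methoxy at this spot does, so there is no direct guide.

The expectation for compound 3 is therefore a number close to that of compound 2, with the step of a 1.0-fold higher number from compound 2 to compound 3 (0.00 log units; within the scatter) estimated to fall within or near the scatter. Compound 3 is thus estimated at 40 nM, in a range from 10 nM to 160 nM.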

Compound 3, half-maximal inhibitory concentration: 31.6 nM
Compound 3: the middle estimate sits 1.3-fold (0.10 log units) above what was measured, within the range that was stated.
By their numbers in this assay, from the lowest: compounds 3 and 2 (each within the scatter of the next); then compound 1.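

In this assay the step from hydrogen to methoxy, on an aromatic carbon ortho to a large group, is a 1.3-fold lower number from compound 2 to compound 3 (0.10 log units; within the scatter) and so cannot be told apart from repeat-measurement scatter, which means this position can carry a methoxy with no detectable cost or gain. The large benefit of building out this end of the molecule also remains when the added ring is decorated: 2-methoxyphenyl in place of hydrogen gives a 500-fold lower number from compound 1 to compound 3 (2.70 log units; beyond the scatter) and stands on the same large scale as the plain phenyl, which gave a 400-fold lower number from compound 1 to compound 2 (2.60 log units; beyond the scatter) from the same starting point. No supporting data on how or why these compounds differ are available to explain this tolerance.

One small group at one position says little about how much room or what kind of group this spot will accept, so an amine, a carboxylic acid or a longer chain such as butoxy could behave quite differently. Going by these compounds, it also remains open whether methoxy on another carbon of this ring, or on the ring of compound 1, would leave the number just as undisturbed.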